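Notes on the step from compound 3 to compound 4

The compounds below may be only part of what the source reports. "The series", "measured", "known", "first", "only" and "open" are said of these compounds alone.

Measured in a functional assay on HepG2 cells (Homo sapiens) for cytotoxicity, read by MTT assay, with a stated time of 72 h; a higher number here means a weaker inhibitor, a lower number a stronger inhibitor
- compound 1 `O=C(N/N=C/c1ccc(F)cc1)Nc1cc2c(Nc3ccc(F)c(Cl)c3)ncnc2cc1O[C@H]1CCOC1` gives "not active" (no number reported) (no number reported)
- compound 2 `CCN(CC)c1ccc(/C=N/NC(=O)Nc2cc3c(Nc4ccc(F)c(Cl)c4)ncnc3cc2O[C@H]2CCOC2)c(O)c1` gives 15700 nM
- compound 3 `COc1cc2ncnc(Nc3ccc(F)c(Cl)c3)c2cc1NC(=O)N/N=C/c1ccc(F)cc1` gives 31100 nM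

Compound 3 (31100 nM) lies within the scatter of compound 2 (15700 nM), and compound 1 offers no number for comparison. Compound 4 `COc1cc2ncnc(Nc3ccc(F)c(Cl)c3)c2cc1NC(=O)N/N=C/c1ccc(F)cc1Cl` takes chloro in place of hydrogen on an aromatic carbon, 4-fluorophenyl to 2-chloro-4-fluorophenyl (chloro in place of hydrogen on an aromatic carbon). Going by the values given here, no measured pair differs in one place only, so the data give no direct guide to this change, and no shift beyond the scatter is expected in this assay. The expected change (a 1.2-fold lower number from compound 3 to compound 4 (0.09 log units; within the scatter)) has no firm direction. The estimate for compound 4 is 25000 nM with a range of 10000 nM to 60000 nM (expected, not measured).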

Compound 4, half-maximal inhibitory concentration: 29200 nM
The estimate for compound 4 lay 1.2-fold (0.07 log units) below the measured number, within the range that was stated.
By their numbers in this assay, from the lowest: compounds 2, 4 and 3 (each within the scatter of the next).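

In this assay, going by these compounds alone, chloro in place of hydrogen on an aromatic carbon, ortho to a large group and meta to a fluoro group, gives the only single-place step available for this series (a 1.1-fold lower number from compound 3 to compound 4 (0.03 log units; within the scatter)). At this position, the change from 4-fluorophenyl to 2-chloro-4-fluorophenyl therefore stays within the scatter. No supporting data bear on this result.

From the compounds shown here alone, how an amine or a carboxylic acid on this aromatic carbon would read in this assay remains open. Also open, going by these compounds, is whether chloro here would give a number on the core of compound 1, which has none.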